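Extending the amide chain on a nitro-sulfonamide core

The compounds below may be only part of what the source reports. "The series", "measured", "known", "first", "only" and "open" are said of these compounds alone.

Compound 1, `CNC(=O)CC[C@H](NS(=O)(=O)c1ccc([N+](=O)[O-])cc1)C(=O)O`, carries a methylcarbamoyl end on its side chain. For the measured compounds named here, in an assay for inhibition of matrix metalloproteinase-9 (Homo sapiens), with stated times of 1 h, 1 min and 30 min (a higher number here means a weaker inhibitor, a lower number a stronger inhibitor), compound 1 gives 7500 nM, which is the highest of the two numbers measured so far. Its nearest neighbour is compound 2, `CC(C)CNC(=O)CC[C@H](NS(=O)(=O)c1ccc([N+](=O)[O-])cc1)C(=O)O`, which in this assay gives 5140 nM; the change from compound 1 to compound 2 is a 1.5-fold lower number from compound 1 to compound 2 (0.16 log units; within the scatter), so the two values cannot be told apart.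

Compound 3, `CCCCCNC(=O)CC[C@H](NS(=O)(=O)c1ccc([N+](=O)[O-])cc1)C(=O)O`, has not yet been measured. It differs from compound 1 by butyl in place of hydrogen on a saturated chain carbon bound to an amide-type nitrogen. Going by the values given here, the only measured step that bears on this, from compound 1 to compound 2, also enlarged the chain at the same place and stayed within the scatter. Lengthening the chain further is therefore expected to give a 1.5-fold lower number from compound 1 to compound 3 (0.18 log units; within the scatter), no more than the scatter allows. Compound 3 is accordingly estimated at 5000 nM, with a likely range from 2000 nM to 12000 nM.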

Compound 3, half-maximal inhibitory concentration: 6800 nM
Estimate against measurement, compound 3: 1.4-fold (0.13 log units) below; measured number inside the range.
By their numbers in this assay, from the lowest: compounds 2, 3 and 1 (each within the scatter of the next).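

Putting butyl in place of hydrogen on a saturated chain carbon bound to an amide-type nitrogen, which turns methylcarbamoyl into pentylcarbamoyl, gives a 1.1-fold lower number from compound 1 to compound 3 (0.04 log units; within the scatter) in this assay, so even this larger change leaves compound 3 indistinguishable from compound 1. Butyl in place of isopropyl at the same place gives a 1.3-fold higher number from compound 2 to compound 3 (0.12 log units; within the scatter), so the isopropyl and butyl versions cannot be told apart either, and none of the three chains shown stands out. Nothing measured explains why these chains give such similar numbers.

As far as these compounds go, whether an amine, a carboxylic acid or a phenyl ring in this place, or a chain longer than pentyl, would move the number beyond the scatter remains open. From the compounds shown here alone, all three compounds also share one core, so the effect of changes to that core is unknown.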